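Oxygen for Sulfur on the Fused Core

This account rests on a few compounds, and the source may have more. Where it says the series, first, only, none or still open, it means among the compounds named here.

The series shares the core of compound 1 `Nc1cc(N)c2nc(-c3ccccc3)c(Oc3ccc(Cl)c(Cl)c3)nc2c1`, which carries a 3,4-dichlorophenoxy group; in a functional assay on CAKI-1 cells (Homo sapiens) for inhibition, read by sulforhodamine B assay, with a stated time of 48 h (on this read-out higher numbers stand for weaker inhibition of growth and lower numbers for stronger inhibition of growth), compound 1 gives 15800 nM. Compound 2 `Nc1cc(N)c2nc(-c3ccccc3)c(NCc3ccc(Cl)c(Cl)c3)nc2c1` differs from compound 1 only in the group attached at the same place, and in this assay compound 2 gives 13200 nM, a value within the usual scatter of that of compound 1. Compound 3 `Nc1cc(N)c2nc(-c3ccccc3)c(Sc3ccc(F)cc3)nc2c1` carries (4-fluorophenyl)sulfanyl there. In this assay compound 3 gives only a limit, < 100000 nM, so its standing among the numbers is not known. Within the data shown here, the step that the limit leaves unreadable from compound 1 to compound 3 cannot be read for that reason, and the limit of < 100000 nM in this assay, at which 1 of the 3 values shown sits, is the only evidence bearing on compound 3.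

Compound 4 `Nc1cc(N)c2nc(-c3ccccc3)c(Oc3ccc(F)cc3)nc2c1` is the next member. 4-fluorophenoxy in place of (4-fluorophenyl)sulfanyl on an aromatic carbon The 4-fluorophenyl ring is kept and only the linking atom changes, so the oxygen linkage of compound 1 returns with a different ring. Among the measured compounds shown here, no measured step covers this exchange; the only readable value with an oxygen linkage is that of compound 1. The step that the limit leaves unreadable from compound 3 to compound 4 that the estimate means is expected to begin from a limit rather than a number. Compound 4 is expected to give about 30000 nM in this assay, within 8000 nM to 100000 nM.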

Compound 4, concentration for 50% growth inhibition: 11200 nM
Beside the measured number, compound 4's estimate is 2.7-fold (0.43 log units) above it, and the stated range covers the measured number.
By their numbers in this assay, from the lowest: compounds 4, 2 and 1 (each within the scatter of the next).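

Working from the oxygen linkage at this position, on an aromatic carbon next to the ring nitrogen, the exchange of 3,4-dichlorophenyl for 4-fluorophenyl on the oxygen gives a 1.4-fold lower number from compound 1 to compound 4 (0.15 log units; within the scatter). In this assay, among these compounds, the ring on the oxygen can therefore change in this way without a readable shift, and compound 4 gives 11200 nM, the first number for a 4-fluorophenyl ring at this position. The exchange of sulfur for oxygen in the linkage stays unresolved, and the steps that begin or end at compound 3 cannot be read because the only evidence on that compound is a limit and not a number: the limit of < 100000 nM in this assay, at which 1 of the 4 values shown sits.

Open, on these data alone, is whether sulfur and oxygen linkages differ at all when the ring on them is the same, which would take a number for a sulfur-linked compound in place of a limit. Also open, as far as these compounds go, is how the read-out responds at this position to a group of another kind, such as an unsubstituted phenoxy, a carboxylic acid on the ring or a longer chain in the linkage.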